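The compounds below may be only part of what the source reports. "The series", "measured", "known", "first", "only" and "open" are said of these compounds alone.

Compound 2 `Nc1ccc2cccc(OCC3CCCC3)c2n1` gives 53 nM in an assay on cells with melanin-concentrating hormone receptor 1 (Homo sapiens) as the target, read by radioligand binding (a higher number here means a weaker inhibitor, a lower number a stronger inhibitor), the lowest of the two numbers in hand; compound 1 `COCC(C)Oc1cccc2ccc(N)nc12` gives 606 nM in this assay. Within the data shown here, the single measured step, an 11-fold lower number from compound 1 to compound 2 (1.06 log units; beyond the scatter), shows that the group on the aromatic oxygen carries much weight here. Compound 3 `CC#CCCOc1cccc2ccc(N)nc12` differs from compound 2 by but-2-yn-1-yl in place of cyclopentyl on a saturated chain carbon bound to an oxygen on an aromatic ring. Among the measured compounds shown here, no measured step covers this exchange directly; the step from compound 1 to compound 2 shows only that a change in this part of the molecule can move the number a long way. Giving up the five-membered ring of compound 2 for the open but-2-yn-1-yl chain is expected to shift the number modestly toward the weaker side, with wide uncertainty. For compound 3 the expected step is a 2.5-fold higher number from compound 2 to compound 3 (0.39 log units; beyond the scatter). Compound 3 is estimated at 130 nM, with a range from 40 nM to 450 nM.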

Compound 3, half-maximal inhibitory concentration: > 2000 nM
Compound 3 gave a limit, no number (the forecaster's own chance of this, stated with the estimate: 3%); middle value at least 15-fold (1.18 log units) away from the limit.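

In this assay compound 3 gives a limit of the assay and not a number: the limit of > 2000 nM in this assay, at which 1 of the 3 values shown sits.

The exchange of cyclopentyl for but-2-yn-1-yl brings an at least 37-fold higher number from compound 2 to compound 3 (1.57 log units; beyond the scatter), so the gain seen with cyclopentylmethyl on the aromatic oxygen does not carry over to this open chain, even though only one heavy atom separates the two groups. The pent-3-yn-1-yl group also falls behind the 1-(methoxymethyl)ethyl group, with an at least 3.3-fold higher number from compound 1 to compound 3 (0.51 log units; beyond the scatter), so the position can lose as well as gain against the earlier weaker compound.

The compounds shown leave open whether the loss goes with the opening of the ring or with the triple bond, which a saturated pentyl chain on the same oxygen could separate. They also leave open how a cyclohexylmethyl group would compare with cyclopentylmethyl.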